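The compounds below may be only part of what the source reports. "The series", "measured", "known", "first", "only" and "open" are said of these compounds alone.

In an ADME assay on HepG2 2.2.15 cells (Homo sapiens) for cytotoxicity (a higher number here means that more compound is tolerated, a lower number that less compound is tolerated), three compounds have been examined so far. Compound 1 `O=C(Nc1ncc(Cc2ccc(Cl)cc2)s1)c1cccs1` gives > 50000 nM, which is a limit of the assay rather than a number. Compound 2 `O=C(Nc1ncc(C(OCc2ccc(Br)cc2)c2ccccc2)s1)c1cccs1` is recorded in this assay as "not toxic" (no number reported), without any number. Compound 3 `CC(C)(C)C(=O)Nc1ncc(C(Oc2ccc3cc(Br)ccc3c2)c2ccc(Cl)cc2)s1` likewise stands in this assay at "not toxic" (no number reported), and no single number marks where it sits. One of the three values shown rests at the limit of > 50000 nM in this assay, at which 1 of the 3 values shown sits, and a further entry carries no number at all. Nothing in these three entries sets one compound apart from another in this assay.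

Compound 4 `N#Cc1cccc(C(=O)Nc2ncc(C(Oc3ccc4cc(Br)ccc4c3)c3ccc(Cl)cc3)s2)c1` has not yet been measured in this assay. It differs from compound 3 in one place: 3-cyanophenyl in place of tert-butyl on a carbonyl carbon. Going by the values given here, no measured pair shows this change, and its effect can be judged from the three entries alone. None of them reaches a number within the tested range; the step from compound 3 to compound 4 in this assay is expected to be none beyond the scatter, with no direction to it. Compound 4 is estimated in this assay at 50000 nM, within a range from 20000 nM to 100000 nM, and the assay may well again report only a limit.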

Compound 4, half-maximal cytotoxic concentration: > 50000 nM
Compound 4 ended at the assay's limit (the forecaster's own chance of this, stated with the estimate: 70%); the middle value lies on the limit itself.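

In this assay, going by these compounds alone, compound 4 gives > 50000 nM, which is a limit and not a number, and compound 3 carries no number, so no step from compound 3 to compound 4 can be read. The compounds shown leave open what concentration any of them would take to become toxic, and whether 3-cyanophenyl in place of tert-butyl changes tolerance at all, with the readings stopping here: the limit of > 50000 nM in this assay, at which 2 of the 4 values shown sit.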